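From 2-fluorophenyl to 3-(trifluoromethyl)phenyl: compound 3 to compound 4

The compounds below may be only part of what the source reports. "The series", "measured", "known", "first", "only" and "open" are said of these compounds alone.

Compound 1 `O=Cc1ccc(-c2cc(Cl)cn3c([N+](=O)[O-])c(CS(=O)(=O)c4ccccc4)nc23)cc1`: > 31200 nM
Compound 2 `O=[N+]([O-])c1c(CS(=O)(=O)c2ccccc2)nc2c(-c3ccc(F)cc3)cc(Cl)cn12`: > 15600 nM
Compound 3 `O=[N+]([O-])c1c(CS(=O)(=O)c2ccccc2)nc2c(-c3ccccc3F)cc(Cl)cn12`: > 3900 nM

These results come from an ADME assay on HepG2 cells (Homo sapiens) for cytotoxicity, read by MTT assay, with a stated time of 72 h (a lower number here means that less compound is tolerated, a higher number that more compound is tolerated), and each one is a limit of the assay, not a number. Compound 3 therefore has only a limit, > 3900 nM.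

Compound 4 `O=[N+]([O-])c1c(CS(=O)(=O)c2ccccc2)nc2c(-c3cccc(C(F)(F)F)c3)cc(Cl)cn12` keeps the shared core and has 3-(trifluoromethyl)phenyl in place of 2-fluorophenyl on an aromatic carbon.

Two measured changes involve the same aromatic carbon: a step that the two limits leave unreadable from compound 2 to compound 3 and a step that the two limits leave unreadable from compound 1 to compound 3. Neither gives a size to carry over, so no particular step can be read from them. In this assay, a high value is still expected, and quite possibly another limit, as with all three measured compounds.

The expected change is a step that the limit leaves unreadable from compound 3 to compound 4, a rough estimate pointing upward. For compound 4 the estimated value is 10000 nM, with an expected range from 3900 nM to 31200 nM.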

Compound 4, half-maximal cytotoxic concentration: > 12500 nM
Compound 4: only a limit was reported; the forecaster's own chance of this, stated with the estimate: 80%; at least 1.2-fold (0.09 log units) between middle value and limit.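

For the compounds shown here, compound 4 gives only a limit in this assay, as do compound 1, compound 2 and compound 3, so no step to compound 4 can be read. The compounds shown leave open whether changing the group on this aromatic carbon alters the half-maximal cytotoxic concentration at all, and by how much.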